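Chloro on the Fused Ring of the Benzothiazole Amines

The source may hold more compounds than are shown below. What is called first, only, known or untested is meant among the compounds shown, and "the series" means these compounds.

Measured so far:
compound 1, `CS(=O)(=O)c1ccc(Nc2ncc(F)c(Nc3nc4ccccc4s3)n2)cc1`: 3170 nM
compound 2, `Cc1cnc(Nc2ccc(S(N)(=O)=O)cc2)nc1Nc1nc2ccccc2s1`: 2800 nM
compound 3, `CS(=O)(=O)c1ccc(Nc2ncc(F)c(Nc3nc4ccc(Cl)cc4s3)n2)cc1`: > 50000 nM

Of the compounds shown here, three have been tested in a functional assay on HeLa cells (Homo sapiens) for antiproliferative activity, read by MTT assay, with a stated time of 48 h; on this read-out lower numbers stand for stronger inhibition and higher numbers for weaker inhibition. Compound 1 and compound 2 share a related core, but how their two cores differ is not broken down here; in this assay compound 1 gives 3170 nM and compound 2 gives 2800 nM, two numbers that sit within the scatter of each other. For compound 3 this assay reports only a limit, > 50000 nM.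

Compound 3 arises from compound 1 by one change, (chloro in place of hydrogen on an aromatic carbon). That change produced an at least 15-fold higher number from compound 1 to compound 3 (1.19 log units; beyond the scatter). The step can only be given as a bound because the limit of > 50000 nM in this assay, at which 1 of the 3 values shown sits, is where compound 3 sits.

Compound 4, `Cc1cnc(Nc2ccc(S(N)(=O)=O)cc2)nc1Nc1nc2ccc(Cl)cc2s1`, is not yet measured. It arises from compound 2 by the same change, (chloro in place of hydrogen on an aromatic carbon), at a place described in the same words as for compound 3. The expectation for compound 4 rests on a single precedent, the step from compound 1 to compound 3, and on the starting number of compound 2, 2800 nM. On that basis compound 4 is expected to show a 13-fold higher number from compound 2 to compound 4 (1.10 log units; beyond the scatter) in this assay, a step of the same direction as the earlier one. Compound 4 is accordingly estimated at 35000 nM, with a range from 10000 nM to 100000 nM, and a real chance that this assay again returns only a limit.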

Compound 4, half-maximal inhibitory concentration: 3730 nM
Compound 4: the middle estimate sits 9.4-fold (0.97 log units) above what was measured; measured number below the stated range.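

In this assay, chloro in place of hydrogen on an aromatic carbon gave a 1.3-fold higher number from compound 2 to compound 4 (0.12 log units; within the scatter), so on this core the change left no difference that can be told from the scatter of repeated measurements. The change therefore did not carry over from the core of compound 1 to the core of compound 2 with anything like the same size, and a large step on one core proved a poor guide to the step on the other: the same change on two cores in this assay, an at least 15-fold higher number (1.19 log units; beyond the scatter) from compound 1 to compound 3 and a 1.3-fold higher number (0.12 log units; within the scatter) from compound 2 to compound 4, at least 11-fold (1.07 log units) apart, beyond the scatter of two such steps Compound 3 is reported only as a limit, and with a single pair of compounds on each core, the data do not show which difference between the two cores sets the steps apart: the limit of > 50000 nM in this assay, at which 1 of the 4 values shown sits.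

The compounds shown leave open whether a group other than chloro on the same aromatic carbon, such as methoxy, an amine or a carboxylic acid, would also separate the two cores. They also leave open which part of each core matters, a question that pairs differing only in the fluoro or methyl group, or only in the methylsulfonyl or sulfonamide group, could begin to settle.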